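The compounds below may be only part of what the source reports. "The series", "measured", "known", "first", "only" and "open" are said of these compounds alone.

Measured in a functional assay on M21 cells (Homo sapiens) for antiproliferative activity, read by sulforhodamine B assay, with a stated time of 48 h; on this read-out lower numbers stand for stronger inhibition and higher numbers for weaker inhibition:
compound 1 `O=C1NCCN1c1ccc(S(=O)(=O)Nc2ccc(C3CCCCC3)cc2)cc1`: > 1000 nM
compound 2 `O=C1NCCN1c1ccc(S(=O)(=O)Nc2ccc(F)cc2)cc1`: 230 nM
Not yet measured:
compound 3 `CCCCc1ccc(NS(=O)(=O)c2ccc(N3CCNC3=O)cc2)cc1`

Compound 1 shows > 1000 nM, and this entry is a limit of the assay and not a number. For the measured compounds named here, compound 2, at 230 nM, therefore holds the only true number so far. Compound 3 carries butyl in place of fluoro on an aromatic carbon, para to a large group (butyl in place of fluoro on an aromatic carbon). Going by the values given here, one measured step bears on this change: cyclohexyl gave way to fluoro on an aromatic carbon, with an at least 4.3-fold lower number from compound 1 to compound 2 (0.63 log units; beyond the scatter). Compound 3 again puts a carbon-only group where compound 2 has fluoro, so that step, read backwards, points towards weaker inhibition in this assay. This rests on a single pair, and butyl is not cyclohexyl, so the expectation is a modest one. The expected change is a 2.2-fold higher number from compound 2 to compound 3 (0.34 log units; beyond the scatter). For compound 3 the estimated value is 500 nM, with an expected range of 150 nM to 1700 nM.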

Compound 3, half-maximal inhibitory concentration: 450 nM
Beside the measured number, compound 3's estimate is 1.1-fold (0.05 log units) above it, and the stated range covers the measured number.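

In this assay, butyl in place of fluoro gives a 2.0-fold higher number from compound 2 to compound 3 (0.29 log units; within the scatter), so these two groups cannot be told apart at this position, and a carbon-only group here does not by itself weaken inhibition. Butyl in place of cyclohexyl gives an at least 2.2-fold lower number from compound 1 to compound 3 (0.34 log units; beyond the scatter), which ties the weak result of compound 1 to cyclohexyl and not to every carbon-only group at this position. The true size of that step stays unknown, since the entry for compound 1 is a limit and not a number: the limit of > 1000 nM in this assay, at which 1 of the 3 values shown sits.

The compounds shown leave open whether a longer chain than butyl, or an amine or a carboxylic acid at this position, would keep inhibition at this level. They also leave open how a smaller ring, such as cyclopropyl, would compare with cyclohexyl.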